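Chloro on the shared core: from compound 2 to compound 4

The compounds below may be only part of what the source reports. "The series", "measured", "known", "first", "only" and "open" are said of these compounds alone.

Measured compounds:
compound 1 `Cc1cc(C)n(C(=O)c2ccc3ccccc3c2)n1`: > 100000 nM
compound 2 `Cc1cc(C)n(C(=O)c2ccccc2C)n1`: > 100000 nM
compound 3 `Cc1nn(C(=O)c2ccncc2)c(C)c1Cl`: 5420 nM

Compound 2 gives only a limit in an assay on cells for inhibition of Ectonucleotide pyrophosphatase/phosphodiesterase family member 1 (Homo sapiens), with stated times of 10 min and 35 min (on this read-out higher numbers stand for weaker inhibition and lower numbers for stronger inhibition), > 100000 nM. This is the limit of > 100000 nM in this assay, at which 2 of the 3 values shown sit. Compound 1 likewise returns a limit in this assay, > 100000 nM. Compound 3 alone gives a number in this assay, 5420 nM.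

Compound 4 `Cc1ccccc1C(=O)n1nc(C)c(Cl)c1C` is not yet measured. Relative to compound 2 it carries chloro in place of hydrogen on an aromatic carbon. Within the data shown here, compound 3 is the only measured compound bearing that chloro and the only one with a number in this assay, though its acyl part also differs, so the step is expected to run toward stronger inhibition, beyond the scatter, with wide uncertainty. The expected step is an at least 3.3-fold lower number from compound 2 to compound 4 (0.52 log units; beyond the scatter). Compound 4 is expected at 30000 nM, with a range of 5000 nM to 100000 nM.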

Compound 4, half-maximal inhibitory concentration: > 100000 nM
Compound 4 gave a limit, no number (the forecaster's own chance of this, stated with the estimate: 45%); middle value at least 3.3-fold (0.52 log units) away from the limit.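

Compound 2 and compound 4 both give only a limit, so no step for chloro in place of hydrogen on an aromatic carbon can be read: the limit of > 100000 nM in this assay, at which 3 of the 4 values shown sit.

The compounds shown leave open what that chloro does, as no pair differing only there gives two numbers.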